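This account rests on a few compounds, and the source may have more. Where it says the series, first, only, none or still open, it means among the compounds named here.

Of the compounds shown here, three sharing one core have been measured in a functional assay on SW480 cells (Homo sapiens) for antiproliferative activity, read by MTT assay, with a stated time of 48 h; on this read-out higher numbers stand for weaker inhibition and lower numbers for stronger inhibition. Compound 1 `O=c1cc(-n2cc(COc3cccnc3)nn2)c2cc(Br)ccc2o1` gives 39800 nM. Compound 2 `O=c1cc(-n2cc(COc3ccccc3Br)nn2)c2cc(Br)ccc2o1` gives 20100 nM in this assay, and the step between these first two is a 2.0-fold lower number from compound 1 to compound 2 (0.30 log units; within the scatter). Compound 3 `Nc1ccc(OCc2cn(-c3cc(=O)oc4ccc(Br)cc34)nn2)cc1` gives 2090 nM in this assay, the lowest of the three numbers; the steps leading to it are a 19-fold lower number from compound 1 to compound 3 (1.28 log units; beyond the scatter) and a 9.6-fold lower number from compound 2 to compound 3 (0.98 log units; beyond the scatter), both beyond the scatter.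

Compound 4 `COC(=O)c1ccc(OCc2cn(-c3cc(=O)oc4ccc(Br)cc34)nn2)cc1` has not yet been measured. It differs from compound 3 in one place: methoxycarbonyl in place of amino on an aromatic carbon. Among the measured compounds shown here, no measured step alters a group on this ring; the two large steps exchanged one ring for another, so they bear on compound 4 only loosely, showing that the group at the end of the chain can move this assay considerably. Compound 3, which carries the amino group, gave 2090 nM; exchanging that group is expected to raise the number, by roughly a 3.8-fold higher number from compound 3 to compound 4 (0.58 log units; beyond the scatter). Compound 4 is therefore estimated at 8000 nM in this assay, with a range from 2000 nM to 32000 nM.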

Compound 4, half-maximal inhibitory concentration: 3620 nM
Beside the measured number, compound 4's estimate is 2.2-fold (0.34 log units) above it, and the stated range covers the measured number.
By their numbers in this assay, from the lowest: compounds 3 and 4 (each within the scatter of the next); then compounds 2 and 1 (each within the scatter of the next).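

In this assay, putting methoxycarbonyl in place of amino on an aromatic carbon, para to a large group, gives a 1.7-fold higher number from compound 3 to compound 4 (0.24 log units; within the scatter) and so stays within the scatter. Among the compounds shown here, this is the first measured change to a group on this ring rather than a swap of the ring itself, and it shows that four heavy atoms with no hydrogen-bond donor can replace one heavy atom with one donor without a change that can be told from the scatter. Nothing measured here bears on why these two groups read alike.

From the compounds shown here alone, two groups at one position cannot show a trend, so it remains open whether a carboxylic acid, a hydroxyl or a dimethylamino group would read alike there. Going by these compounds, it is also open whether amino or methoxycarbonyl would hold this level on another carbon of the ring.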